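A few compounds are considered here, and "the series" means these few. Any claim that something is new, unique, unknown or untested is made for them only; others in the source may bear on it.

Compound 2 `CC[C@H]1OC(=O)[C@H](C)[C@@H](O[C@H]2C[C@@](C)(OC)[C@@H](O)[C@H](C)O2)[C@H](C)[C@@H](O[C@@H]2O[C@H](C)C[C@H](N(C)C)[C@H]2OCCCNc2ccnc3cc(Cl)ccc23)[C@](C)(O)C[C@@H](C)CN(C)[C@H](C)[C@@H](O)[C@]1(C)O` was measured in a physicochemical assay for solubility, at pH 4 (on this read-out lower numbers stand for lower solubility and higher numbers for higher solubility), and its result is a limit of the assay rather than a number: compound 2 gives > 10000 ug/mL. Compound 1 `CC[C@H]1OC(=O)[C@H](C)[C@@H](O[C@H]2C[C@@](C)(OC)[C@@H](O)[C@H](C)O2)[C@H](C)[C@@H](O[C@@H]2O[C@H](C)C[C@H](N(C)C)[C@H]2OCCCNC(=O)CCCNc2ccnc3ccccc23)[C@](C)(O)C[C@@H](C)CN(C)[C@H](C)[C@@H](O)[C@]1(C)O` likewise ends at a limit in this assay, where compound 1 gives > 10000 ug/mL. Compound 3 `CC[C@H]1OC(=O)[C@H](C)[C@@H](O[C@H]2C[C@@](C)(OC)[C@@H](O)[C@H](C)O2)[C@H](C)[C@@H](O[C@@H]2O[C@H](C)C[C@H](N(C)C)[C@H]2OCCC(=O)NCCNc2ccnc3cc(Cl)ccc23)[C@](C)(O)C[C@@H](C)CN(C)[C@H](C)[C@@H](O)[C@]1(C)O` also stops at a limit in this assay, where compound 3 gives > 10000 ug/mL. Going by the values given here, all three values thus rest at the limit of > 10000 ug/mL in this assay, at which 3 of the 3 values shown sit, so no sized step between measured compounds can be read. Compound 4 `CC[C@H]1OC(=O)[C@H](C)[C@@H](O[C@H]2C[C@@](C)(OC)[C@@H](O)[C@H](C)O2)[C@H](C)[C@@H](O[C@@H]2O[C@H](C)C[C@H](N(C)C)[C@H]2OCCCNCc2ccc3ccccc3n2)[C@](C)(O)C[C@@H](C)CN(C)[C@H](C)[C@@H](O)[C@]1(C)O` differs from compound 2 by (quinolin-2-yl)methyl in place of 7-chloroquinolin-4-yl on an amine nitrogen. With every measured value resting at the limit, the expected step is a number no higher from compound 2 to compound 4 (the limit leaves the size open), nothing beyond the scatter. Compound 4 is estimated to give 10000 ug/mL in this assay, within 4000 ug/mL to 20000 ug/mL, most likely again reported only as a limit.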

Compound 4, solubility: > 10000 ug/mL
Compound 4 ended at the assay's limit; the forecaster's own chance of this, stated with the estimate: 80%; the middle value sits exactly at the limit.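

Going by these compounds alone, compound 2 and compound 4 both stop at a limit in this assay, so no step between them can be read: the limit of > 10000 ug/mL in this assay, at which 4 of the 4 values shown sit. The compounds shown leave open how the four rank in this assay, and which structural change would bring a value within the measurable range.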